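This account rests on a few compounds, and the source may have more. Where it says the series, first, only, none or still open, it means among the compounds named here.

Of the compounds shown here, two with the same core have been tested in a functional assay on cells for antagonist activity at Glucagon receptor (Homo sapiens), read by luminescence and cAMP accumulation, with stated times of 10 min and 30 min; on this read-out higher numbers stand for weaker inhibition and lower numbers for stronger inhibition. Compound 1 `CCCCC(Oc1ncc(-c2ccccc2)cn1)c1ccc(C(=O)NCCC(=O)O)cc1` gives 4100 nM. Compound 2 `CCCCC(Oc1ncc(-c2cc(Cl)cc(Cl)c2)cn1)c1ccc(C(=O)NCCC(=O)O)cc1` gives 6900 nM, the highest of the two numbers, although the step of a 1.7-fold higher number from compound 1 to compound 2 (0.23 log units; within the scatter) is within the scatter. Compound 3 `CCCCC(Oc1ncc(-c2ccc(CC)cc2)cn1)c1ccc(C(=O)NCCC(=O)O)cc1` carries 4-ethylphenyl in place of 3,5-dichlorophenyl on an aromatic carbon. Within the data shown here, the one measured step bears only loosely on this change, and a step of a 1.5-fold lower number from compound 2 to compound 3 (0.19 log units; within the scatter) is expected, not beyond the scatter. Compound 3 is therefore estimated at 4500 nM in this assay, with a range from 1500 nM to 14000 nM.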

Compound 3, half-maximal inhibitory concentration: 17700 nM
Estimate against measurement, compound 3: 3.9-fold (0.59 log units) below; the measured number lies above the stated range.
By their numbers in this assay, from the lowest: compounds 1 and 2 (each within the scatter of the next); then compound 3.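

Ethyl in place of hydrogen on the phenyl ring gives a 4.3-fold higher number from compound 1 to compound 3 (0.64 log units; beyond the scatter), and 4-ethylphenyl in place of 3,5-dichlorophenyl gives a 2.6-fold higher number from compound 2 to compound 3 (0.41 log units; beyond the scatter), so the choice of group on this ring can move the number beyond the scatter. The earlier step between compound 1 and compound 2 did not show this. Going by these compounds, whether a methyl, a methoxy or an amine on that ring would keep the number close to that of compound 1 remains open. No other kind of data accompanies these numbers to explain the shift.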